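Propyl to benzyl on the amide of a shared core

This account rests on a few compounds, and the source may have more. Where it says the series, first, only, none or still open, it means among the compounds named here.

Three amides on a shared core were tested in an assay on isolated protein for inhibition of NEDD8-activating enzyme E1 regulatory subunit (Homo sapiens), read by Western blot, with stated times of 10 min and 30 min, tested at 25 uM; on this read-out lower numbers stand for less inhibition and higher numbers for more inhibition at the one concentration tested (going by the name of the read-out). Compound 1 `CCCNC(=O)c1cccc2nc(OCC)n(Cc3ccc(-c4ccccc4-c4nnn[nH]4)cc3)c12` gives 32.6% in this assay, the second highest of three numbers. Compound 2 `CCOc1nc2cccc(C(=O)NCCCN(C)C)c2n1Cc1ccc(-c2ccccc2-c2nnn[nH]2)cc1` gives 29.5%, a step of a number 3.1 percentage points lower from compound 1 to compound 2 (within the scatter). Compound 3 `CCOC(=O)CNC(=O)c1cccc2nc(OCC)n(Cc3ccc(-c4ccccc4-c4nnn[nH]4)cc3)c12` gives 46.5%, reached by a number 13.9 percentage points higher from compound 1 to compound 3 (beyond the scatter) and by a number 17 percentage points higher from compound 2 to compound 3 (beyond the scatter). Compound 4 `CCOc1nc2cccc(C(=O)NCc3ccccc3)c2n1Cc1ccc(-c2ccccc2-c2nnn[nH]2)cc1` differs from compound 1 by phenyl in place of ethyl on a saturated chain carbon bound to an amide-type nitrogen. For the measured compounds named here, no measured step exchanges ethyl for phenyl at this place; the two steps that go beyond the scatter both bring in ethoxycarbonyl, and the one step that leaves ethyl untouched stays within the scatter. A step of a number 3.4 percentage points higher from compound 1 to compound 4 (within the scatter) is therefore expected, lying within the scatter. Compound 4 is estimated at 36%, between 20% and 52%.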

Compound 4, a percentage reported as inhibition, at one concentration (the size of the read-out at that concentration, not a potency): 48.9%
Beside the measured number, compound 4's estimate is 12.9 percentage points below it, and the stated range covers the measured number.
By their numbers in this assay, from the lowest: compounds 2 and 1 (each within the scatter of the next); then compounds 3 and 4 (each within the scatter of the next).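

On the amide of the shared core, phenyl in place of ethyl moves the number in this assay beyond the scatter (a number 16.3 percentage points higher from compound 1 to compound 4 (beyond the scatter)), so ethoxycarbonyl is no longer the only group shown to do so at this place. Compound 4 stands level with the ethoxycarbonyl amide (a number 2.4 percentage points higher from compound 3 to compound 4 (within the scatter)) and apart from the dimethylamino amide (a number 19.4 percentage points higher from compound 2 to compound 4 (beyond the scatter)). Nothing available here explains the shift. Left open is whether a phenethyl chain, a substituted phenyl or the carboxylic acid of the ethyl ester would hold this level at the same place.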